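The source may hold more compounds than are shown below. What is called first, only, known or untested is meant among the compounds shown, and "the series" means these compounds.

Going by the values given here, in a physicochemical assay for solubility, read by HPLC, with a stated time of 24 h (on this read-out higher numbers stand for higher solubility and lower numbers for lower solubility), compound 2 `CC(C)(C)c1[nH]cnc1/C=c1\[nH]c(=O)/c(=C/c2cccc(C(=O)N3CCCC3)c2)[nH]c1=O` gives 0.454 ug/mL, the only actual number so far. Compound 1 `O=C(c1ccccc1)c1cccc(/C=c2\[nH]c(=O)/c(=C/c3ccccn3)[nH]c2=O)c1` reports only a limit, < 0.1 ug/mL. Compound 3 `CC(C)(C)c1[nH]cnc1/C=c1\[nH]c(=O)/c(=C/c2cccc(C(=O)c3ccsc3)c2)[nH]c1=O` keeps the core of compound 2 but has thiophen-3-yl in place of pyrrolidin-1-yl on a carbonyl carbon. Among the compounds with values here, no measured step covers this change, so the expectation rests on a loose comparison with compound 1, which also has an aromatic ring on a carbonyl carbon. A downward move in this assay beyond the usual scatter is expected, an estimated step of a 3.8-fold lower number from compound 2 to compound 3 (0.58 log units; beyond the scatter). The estimate for compound 3 is 0.12 ug/mL, with an expected range of 0.05 ug/mL to 0.35 ug/mL.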

Compound 3, solubility: < 0.1 ug/mL
Compound 3: only a limit was reported; the forecaster's own chance of this, stated with the estimate: 45%; middle value at least 1.2-fold (0.07 log units) away from the limit.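

In this assay, going by these compounds alone, this is the first step measured at this position: thiophen-3-yl in place of pyrrolidin-1-yl on a carbonyl carbon gives an at least 4.5-fold lower number from compound 2 to compound 3 (0.65 log units; beyond the scatter). With the core of compound 2 kept, this single change takes the read-out from a number to a limit. The value of compound 3 is a limit, so the size of the step is bounded and not fixed: the limit of < 0.1 ug/mL in this assay, at which 2 of the 3 values shown sit.

The compounds shown leave open how a dimethylamino group, a morpholin-4-yl ring or a piperidine ring carrying a carboxylic acid would read on the same carbonyl carbon. They also leave open whether this step would hold on another core.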